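The source may report more compounds than this note shows. Statements on the series, on what has been measured and on what is new or still open speak of the compounds shown alone.

Working notes on the metabolic stability series.

Among the measured compounds shown here, in an ADME assay on microsomes from liver (Homo sapiens) for metabolic stability, read by LC-MS, with a stated time of 10 min, tested at 0.5 uM (a higher number here means that more of the compound is left, a lower number that less of the compound is left), compound 3 `CCN1CCN(CCCN(C[C@H]2Cc3ccccc3CN2)[C@H]2CCCc3cccnc32)CC1` gives 59%, the lowest of the three numbers measured so far. The nearest is compound 1 `c1ccc2c(c1)CN[C@@H](CN(CC[C@H]1CCCNC1)[C@H]1CCCc3cccnc31)C2`, which in this assay gives 93%; the furthest is compound 2 `c1cnc(CN(CCCN2CCNCC2)[C@H]2CCCc3cccnc32)nc1`, which in this assay gives 100%. For the measured compounds named here, the one measured step that differs in a single place is a number 34 percentage points lower from compound 1 to compound 3 (beyond the scatter), a large fall on introducing the (4-ethylpiperazin-1-yl)methyl group.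

Compound 4 `c1ccc2c(c1)CN[C@@H](CN(CCC1CCNCC1)[C@H]1CCCc3cccnc31)C2` is not yet measured. The change from compound 3 is piperidin-4-yl in place of (4-ethylpiperazin-1-yl)methyl on a saturated chain carbon, two bonds along the chain from an amine nitrogen. It undoes the group whose entry accompanied the large fall from compound 1 to compound 3, and puts in its place a piperidin-4-yl, close in kind to the piperidin-3-yl of compound 1. The measured step from compound 1 to compound 3 therefore bears directly on it and points the other way: a rise in this assay of roughly the same size is expected, well beyond the scatter, landing near compound 1.

For compound 4 the expected step is a number 31 percentage points higher from compound 3 to compound 4 (beyond the scatter), giving an estimate of 90%, with a range from 75% to 100%.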

Compound 4, percent of the compound remaining: 66%
Estimate against measurement, compound 4: 24 percentage points above; the whole stated range lies above it.
By their numbers in this assay, from the lowest: compounds 3 and 4 (each within the scatter of the next); then compounds 1 and 2 (each within the scatter of the next).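

The step of a number 27 percentage points lower from compound 1 to compound 4 (beyond the scatter) in this assay shows that this place, on a saturated chain carbon two bonds along the chain from an amine nitrogen, responds to more than the loss of the (4-ethylpiperazin-1-yl)methyl group: piperidin-4-yl in place of piperidin-3-yl is enough to give a change beyond the scatter. With a number 7 percentage points higher from compound 3 to compound 4 (within the scatter) lying within the scatter, the earlier fall a number 34 percentage points lower from compound 1 to compound 3 (beyond the scatter) cannot be tied to the (4-ethylpiperazin-1-yl)methyl group alone, and high numbers here are so far seen only with the piperidin-3-yl of compound 1 among these two-ring-bearing chains. No measurement at hand explains the difference between the two piperidines.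

On these data alone, how a piperidin-2-yl or a morpholin-4-yl would read at this place remains open. Also open, as far as these compounds go, is whether the opposite stereoisomer of the piperidin-3-yl group would keep the number of compound 1 93% on the same core.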